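Swapping Fluoro for Cyano on Compound 1

A few compounds are considered here, and "the series" means these few. Any claim that something is new, unique, unknown or untested is made for them only; others in the source may bear on it.

Among the measured compounds shown here, compound 1 `CC(C)NC(=O)[C@H]1CC[C@@H](n2/c(=N/C(=O)c3ccc(F)c(F)c3)[nH]c3ccc(CN4CCC(C(C)(C)O)CC4)cc32)CC1` is one of two compounds measured in an in vitro ADME assay on microsomes from liver (Rattus norvegicus) for metabolic stability; a higher number here means faster removal of the compound, a lower number slower removal. In this assay compound 1 gives 19 mL.min-1.g-1, the lowest of the two numbers. The other measured compound, compound 2 `CC(C)NC(=O)[C@H]1CC[C@@H](n2/c(=N/C(=O)c3ccc(F)cc3)[nH]c3ccc(CN4CCCCC4)cc32)CC1`, differs from compound 1 in more than one place, and in this assay compound 2 gives 451 mL.min-1.g-1, a higher number that lies beyond the scatter. Since the two structures differ in several places at once, these two values alone cannot be tied to any single change.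

Compound 3 `CC(C)NC(=O)[C@H]1CC[C@@H](n2/c(=N/C(=O)c3ccc(C#N)c(F)c3)[nH]c3ccc(CN4CCC(C(C)(C)O)CC4)cc32)CC1` has not yet been measured. It differs from compound 1 in one place: cyano in place of fluoro on an aromatic carbon. For the measured compounds named here, no measured pair shows this change by itself, so there is no measured step to lean on. The step from compound 1 to compound 3 is expected to be small, a 1.4-fold lower number from compound 1 to compound 3 (0.13 log units; within the scatter), leaning toward slower removal but quite possibly none beyond the scatter. Compound 3 is expected to give about 14 mL.min-1.g-1, within a range from 6 mL.min-1.g-1 to 35 mL.min-1.g-1.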

Compound 3, intrinsic clearance in microsomes: 29 mL.min-1.g-1
Beside the measured number, compound 3's estimate is 2.1-fold (0.32 log units) below it; the range from low to high includes it.
By their numbers in this assay, from the lowest: compounds 1 and 3 (each within the scatter of the next); then compound 2.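

The swap of fluoro for cyano on an aromatic carbon, para to a large group, now has a measured step of its own in this assay: a 1.5-fold higher number from compound 1 to compound 3 (0.18 log units; within the scatter). This read-out therefore does not separate the two groups at this position, even though cyano brings a triple bond and a hydrogen-bond acceptor to the place that fluoro held. Nothing measured here bears on what lies behind this result.

Still open, going by these compounds, is how this assay would respond to other groups at this position, such as a methoxy group, an amine or a carboxylic acid, or to cyano with the neighbouring fluoro removed. Also unknown is whether cyano in place of fluoro would stay within the scatter on a structure that is cleared much faster, such as compound 2, which gives 451 mL.min-1.g-1 and carries a different ring substitution and no hydroxyl-bearing side group.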